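A Side-Chain Change on Compound 2

The compounds below may be only part of what the source reports. "The series", "measured", "known", "first", "only" and "open" are said of these compounds alone.

In an ADME assay on SW1353 cells (Homo sapiens) for cytotoxicity, read by a luciferase reporter, with a stated time of 30 min (on this read-out higher numbers stand for lower toxicity in this test and lower numbers for higher toxicity in this test), compound 1 `O=C(Nc1ccc(N2CCNCC2)cc1)c1cc(-c2ccc(Cl)cc2)on1` gives 1000 nM. Compound 2 `CCCN(C(=O)c1ccc(-c2ccc(Cl)cc2)o1)c1ccc(N2CCNCC2)cc1` is reported only as a limit, > 20000 nM, and has no exact number on this scale.

Compound 3 `Cn1ccnc1CN(C(=O)c1ccc(-c2ccc(Cl)cc2)o1)c1ccc(N2CCNCC2)cc1` differs from compound 2 in one place: 1-methyl-1H-imidazol-2-yl in place of ethyl on a saturated chain carbon bound to an amide-type nitrogen. This puts 1-methyl-1H-imidazol-2-yl in place of ethyl on a saturated chain carbon bound to an amide-type nitrogen, which can also be read as propyl to (1-methyl-1H-imidazol-2-yl)methyl. Going by the values given here, no pair of measured compounds shows what a change of this kind does, and the starting point is a limit rather than a number. In this assay a modest step towards lower numbers is expected, an at least 1.3-fold lower number from compound 2 to compound 3 (0.12 log units; that floor lies within the scatter), though it may not exceed the scatter, and another limit is quite possible. Compound 3 is estimated at 15000 nM, with an expected range from 5000 nM to 40000 nM.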

Compound 3, half-maximal cytotoxic concentration: > 20000 nM
Compound 3: only a limit was reported; the forecaster's own chance of this, stated with the estimate: 55%; middle value at least 1.3-fold (0.12 log units) from the limit.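

Going by these compounds alone, compound 2 and compound 3 are both reported only as limits, so no step between them can be read: the limit of > 20000 nM in this assay, at which 2 of the 3 values shown sit. From the compounds shown here alone, how far either compound lies beyond that limit stays open, and with it what 1-methyl-1H-imidazol-2-yl in place of ethyl does on this scale.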